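The compounds below may be only part of what the source reports. "The series", "measured", "known", "first", "only" and "open" are said of these compounds alone.

Compound 3 `CCCCCNC(=O)Nc1ccc(S(=O)(=O)Oc2ccccc2C(C)C)cc1` gives 4700 nM in a functional assay on HT-1080 cells (Homo sapiens) for antiproliferative activity, read by sulforhodamine B assay, with a stated time of 48 h (on this read-out higher numbers stand for weaker inhibition and lower numbers for stronger inhibition), which places it second highest of the three numbers measured. Its nearest neighbour is compound 1 `CCC(=O)Nc1ccc(S(=O)(=O)Oc2ccccc2C(C)C)cc1`, which gives 2100 nM in this assay; the step of a 2.2-fold higher number from compound 1 to compound 3 (0.35 log units; beyond the scatter) separates them. Furthest away is compound 2 `CC(C)c1ccccc1OS(=O)(=O)c1ccc(NC(=O)C(C)(C)C)cc1`, which gives 11000 nM in this assay, with the step of a 2.3-fold lower number from compound 2 to compound 3 (0.37 log units; beyond the scatter) between the two; the pair of compounds 1 and 2 shows the step of a 5.2-fold higher number from compound 1 to compound 2 (0.72 log units; beyond the scatter).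

Compound 4 `CC(C)c1ccccc1OS(=O)(=O)c1ccc(NC(=O)NC2CCCC2)cc1` differs from compound 3 by cyclopentyl in place of pentyl on an amide-type nitrogen. For the measured compounds named here, every measured step in this set changes the group on the carbonyl carbon, so none of them tests an exchange of a chain for a ring on the amide-type nitrogen; the steps that bear on this position most closely are a 2.2-fold higher number from compound 1 to compound 3 (0.35 log units; beyond the scatter) and a 2.3-fold lower number from compound 2 to compound 3 (0.37 log units; beyond the scatter), both modest. Compound 4 is therefore expected to stay near compound 3, with a step no larger than the scatter, as a 1.2-fold lower number from compound 3 to compound 4 (0.07 log units; within the scatter). Compound 4 is estimated at 4000 nM, within 1500 nM to 12000 nM.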

Compound 4, half-maximal inhibitory concentration: 3900 nM
Compound 4: the middle estimate sits 1.0-fold (0.01 log units) above what was measured; measured number inside the range.
By their numbers in this assay, from the lowest: compounds 1, 4 and 3 (each within the scatter of the next, the first and the last beyond it); then compound 2.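

In this assay, cyclopentyl in place of pentyl on the amide-type nitrogen gives a change within the scatter (a 1.2-fold lower number from compound 3 to compound 4 (0.08 log units; within the scatter)), so here a ring of carbon and an open chain with the same heavy-atom count cannot be told apart. Cyclopentylamino on the carbonyl carbon also stays within the scatter of ethyl (a 1.9-fold higher number from compound 1 to compound 4 (0.27 log units; within the scatter)), but it stands clearly apart from tert-butyl (a 2.8-fold lower number from compound 2 to compound 4 (0.45 log units; beyond the scatter)), which leaves tert-butyl alone at the weak end of this small set. No evidence is at hand to explain these results. The compounds shown leave open whether a cyclohexyl or phenyl ring on this nitrogen would read the same. They also do not show what a shorter chain such as methyl, or a terminal amine or carboxylic acid on the pentyl chain, would do.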